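The source may hold more compounds than are shown below. What is called first, only, known or untested is meant among the compounds shown, and "the series" means these compounds.

Going by the values given here, compound 1 `C/C=C/COC(=O)/C=C(C)/C=C/CC(C)CCCC(C)(C)OC` is one of two compounds measured in a physicochemical assay for lipophilicity (a higher number here means a more lipophilic compound, a lower number a more polar compound), and it stands highest of the two: in this assay compound 1 gives 6.07. Compound 2 `C#CCSC(=O)/C=C(C)/C=C/CC(C)CCCC(C)C` is the nearer neighbour, and in this assay compound 2 gives 5.07, a number beyond the scatter below it. Compound 3 `CCCC(=O)/C=C(C)/C=C/CC(C)CCCC(C)(C)OC` has not yet been measured. It differs from compound 1 in one place: propyl in place of (but-2-en-1-yl)oxy on a carbonyl carbon. With three heavy atoms entering where five leave, a modest drop in this assay is expected, a number 0.52 log units lower from compound 1 to compound 3 (beyond the scatter), so compound 3 is estimated at 5.55, likely between 5 and 6.1.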

Compound 3, partition coefficient: 5.61
Beside the measured number, compound 3's estimate is 0.06 log units below it, within the range that was stated.
By their numbers in this assay, from the lowest: compound 2; then compound 3; then compound 1.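

In this assay, going by these compounds alone, propyl in place of (but-2-en-1-yl)oxy on a carbonyl carbon gives the first step between compounds that differ in one place (a number 0.46 log units lower from compound 1 to compound 3 (beyond the scatter)). This shows that the number at this position responds to the group on the carbonyl carbon while the rest of the molecule stays the same. The change removes an oxygen and a double bond together, and this single step does not separate them.

As far as these compounds go, how an amine or a carboxylic acid on this carbonyl carbon would read remains open. Nothing available explains the size of this step.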